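Dithiocarbamate-linked benzamides: ring nitrogen substituent and HeLa inhibition

This account rests on a few compounds, and the source may have more. Where it says the series, first, only, none or still open, it means among the compounds named here.

Measured so far:
- compound 1 `CC1CCN(C(=S)SCc2ccc(C(=O)Nc3ccccc3N)cc2)CC1`: 72.5%
- compound 2 `Nc1ccccc1NC(=O)c1ccc(CSC(=S)N2CCN(c3ccncc3)CC2)cc1`: 77.4%
- compound 3 `Nc1ccccc1NC(=O)c1ccc(CSC(=S)N(Cc2ccccc2)Cc2ccccc2)cc1`: 18.9%

All three share one core and differ only in the group on the thiocarbonyl nitrogen. In a functional assay on HeLa cells (Homo sapiens) for antiproliferative activity, read by CCK-8 assay, with a stated time of 72 h, tested at 8 uM (on this read-out higher numbers stand for a stronger effect at the one concentration tested and lower numbers for a weaker effect), compound 2 carries the highest of the three numbers, but compound 1 lies within the usual scatter of it, so no order between those two can be read. Compound 3, with two benzyl groups on an open nitrogen, sits far below, beyond the scatter.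

Compound 4 `CN1CCN(C(=S)SCc2ccc(C(=O)Nc3ccccc3N)cc2)CC1` is the next step from compound 2. The change is methyl in place of pyridin-4-yl on an amine nitrogen in a ring. The ring itself stays; only the group on its second nitrogen shrinks.

Among the compounds with values here, no measured pair differing in one place is available, so the size of this step is not known from the data. A small ring substituent is already tolerated, since compound 1 gives 72.5%, so a modest drop at most, possibly none beyond the scatter, is expected. The expected step is a number 9.4 percentage points lower from compound 2 to compound 4 (within the scatter). Compound 4 is estimated at 68%, with a range from 50% to 82%.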

Compound 4, a percentage reported as inhibition, at one concentration (the size of the read-out at that concentration, not a potency): 75.7%
Compound 4: middle estimate off by 7.7 percentage points, on the low side, within the range that was stated.
By their numbers in this assay, from the lowest: compound 3; then compounds 1, 4 and 2 (each within the scatter of the next).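

In this assay, methyl in place of pyridin-4-yl on the amine nitrogen in the ring gives a number 1.7 percentage points lower from compound 2 to compound 4 (within the scatter) and so shows that, at this position, the read-out does not separate a six-membered aromatic ring from a single carbon. With 4-methylpiperazin-1-yl in place of 4-methylpiperidin-1-yl on the thiocarbonyl carbon, the series gives a number 3.2 percentage points higher from compound 1 to compound 4 (within the scatter) and so shows no separation for this exchange either. Nothing on hand offers a reason for either result.

Still open, going by these compounds, is whether a free amine, a carboxylic acid or a longer chain on that ring nitrogen would stay in the same range. On these data alone, whether compound 1, compound 2 and compound 4 would show a stronger or weaker effect at another concentration also remains open, as only the size of the effect at the one concentration tested is known.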